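Compound 4: A Measured Series With No Starting Number

The compounds below may be only part of what the source reports. "The series", "measured", "known", "first", "only" and "open" are said of these compounds alone.

Values in a functional assay on MCF7 cells (Homo sapiens) for cytotoxicity, read by MTT assay, with a stated time of 72 h (on this read-out lower numbers stand for stronger inhibition and higher numbers for weaker inhibition), follow
- compound 1 `CS(=O)(=O)Oc1c(C(=O)NCc2ccc(F)cc2)nc(Br)c2cccnc12` has "not determined" (no result reported)
- compound 2 `Nc1cccc(Nc2c(C(=O)NCc3ccc(F)cc3)nc(Br)c3cccnc23)c1` gives 8000 nM
- compound 3 `CC(C)(C)OC(=O)N1CCN(c2c(C(=O)NCc3ccc(F)cc3)nc(Br)c3cccnc23)CC1` gives > 10000 nM as a limit of the assay, not a number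

As far as these compounds go, compound 1 has no number of its own, so its place on this scale stays open. For compound 3 the data hold the limit of > 10000 nM in this assay, at which 1 of the 3 values shown sits, and nothing finer. The step to follow is (3-(dimethylamino)propyl)amino in place of (methylsulfonyl)oxy on an aromatic carbon and it puts (3-(dimethylamino)propyl)amino in place of (methylsulfonyl)oxy on an aromatic carbon. Compound 4 `CN(C)CCCNc1c(C(=O)NCc2ccc(F)cc2)nc(Br)c2cccnc12` awaits measurement. This step has no measured start, so compound 2 is the nearest guide. Compound 2 gives 8000 nM in this assay and a value close to it is expected, with no gap beyond the usual scatter. The estimated value for compound 4 is 7000 nM with an expected range from 2500 nM to 20000 nM overall.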

Compound 4, half-maximal inhibitory concentration: 7000 nM
Estimate against measurement, compound 4: no gap at the digits printed; the range from low to high includes it.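

On the nitrogen attached to this aromatic carbon, 3-(dimethylamino)propyl in place of 3-aminophenyl gives a 1.1-fold lower number from compound 2 to compound 4 (0.06 log units; within the scatter) in this assay, so an open chain with no ring and a ring-bearing group cannot be told apart in this read-out. The step from compound 1 cannot be read, since compound 1 has no number. Compound 3 remains a limit and not a number: the limit of > 10000 nM in this assay, at which 1 of the 4 values shown sits.

As far as these compounds go, what a longer chain, a morpholine or a carboxylic acid at this position would give remains open. So does whether any group here can reach much lower numbers than compound 4 at 7000 nM.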